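Thiazolyl enones: moving the chlorine round the anilino ring

This account rests on a few compounds, and the source may have more. Where it says the series, first, only, none or still open, it means among the compounds named here.

The measured compounds:
Compound 1, `Cc1nc(Nc2cccc(Cl)c2)sc1C(=O)/C=C/c1ccccc1`, in a functional assay on PC-3 cells (Homo sapiens) for cytotoxicity, read by MTT assay (a lower number here means a stronger inhibitor, a higher number a weaker inhibitor), gives > 25000 nM, which is a limit of the assay rather than a number.
Compound 2, `Cc1ccc(Nc2nc(C)c(C(=O)/C=C/c3ccc(Cl)cc3)s2)cc1`, in this assay gives > 25000 nM, again a limit.
Compound 3, `Cc1nc(Nc2ccc(Cl)cc2)sc1C(=O)/C=C/c1ccc(Cl)cc1`, in this assay gives > 25000 nM, also a limit.

Compound 3 therefore stands nowhere in particular on the scale: its value is only a limit, and the same holds for the two other compounds shown (the limit of > 25000 nM in this assay, at which 3 of the 3 values shown sit). Within the data shown here, the one step that can be read between measured compounds, a step that the two limits leave unreadable from compound 2 to compound 3, has no readable size for the same reason.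

Compound 4, `Cc1nc(Nc2cccc(Cl)c2)sc1C(=O)/C=C/c1ccc(Cl)cc1`, differs from compound 3 by 3-chlorophenyl in place of 4-chlorophenyl on a nitrogen on an aromatic ring. Among the measured compounds shown here, no measured step bears on this change with a readable size, and every compound shown sits at the limit. The step from compound 3 to compound 4 in this assay is therefore expected to be a step that the limit leaves unreadable from compound 3 to compound 4, that is, no change that can be seen. Compound 4 is expected to give 50000 nM, with a range from 25000 nM to 200000 nM, most likely reported again only as a limit.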

Compound 4, half-maximal inhibitory concentration: > 25000 nM
Compound 4: no number, only a limit (the forecaster's own chance of this, stated with the estimate: 85%); the middle value does not contradict the limit.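

Compound 4 also gives only a limit, so its steps from compound 1, compound 2 and compound 3 cannot be read, and all four compounds end up in the same place: the limit of > 25000 nM in this assay, at which 4 of the 4 values shown sit.

The compounds shown leave open whether 3-chlorophenyl and 4-chlorophenyl differ at all, and what change to the shared core would give a readable number in this assay.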